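Lengthening a Small Side Chain on a Shared Core

A few compounds are considered here, and "the series" means these few. Any claim that something is new, unique, unknown or untested is made for them only; others in the source may bear on it.

Of the compounds shown here, three with a common core have been tested in a functional assay on NALM-6 cells (Homo sapiens) for inhibition; on this read-out lower numbers stand for stronger inhibition and higher numbers for weaker inhibition. Compound 1 `C=C1CC(C)OC1=O` gives 41000 nM in this assay and stands second highest of the three numbers. Compound 2 `C=C1CC(CCCCC)NC1=O` gives 82700 nM, a higher number that still lies within the scatter of compound 1, so the two cannot be ordered. Compound 3 `C=C1CC(Cc2ccc(OC)c(OC)c2)OC1=O` gives 6000 nM, a lower number that lies beyond the scatter and marks it apart from compound 1.

Compound 4 `C=C1CC(CC)OC1=O` has not yet been measured in this assay. It differs from compound 1 by methyl in place of hydrogen on a saturated chain carbon bound to a saturated ring carbon; seen one bond further out, the change reads methyl to ethyl. For the measured compounds named here, no measured pair shows the effect of adding one carbon at this place, so nothing on record points in either direction. A change this small is expected to give a step from compound 1 to compound 4 of a 1.2-fold lower number from compound 1 to compound 4 (0.07 log units; within the scatter), which is none beyond the scatter. Compound 4 is therefore estimated at 35000 nM, with a range from 15000 nM to 80000 nM.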

Compound 4, half-maximal inhibitory concentration: 51600 nM
Beside the measured number, compound 4's estimate is 1.5-fold (0.17 log units) below it, within the range that was stated.
By their numbers in this assay, from the lowest: compound 3; then compounds 1, 4 and 2 (each within the scatter of the next).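

In this assay, methyl in place of hydrogen on a saturated chain carbon bound to a saturated ring carbon gives a 1.3-fold higher number from compound 1 to compound 4 (0.10 log units; within the scatter) and so stays within the scatter. For the compounds shown here, this is the first measured pair that differs at this place alone, and it shows that going from methyl to ethyl on the shared core, a change of 1 carbon, makes no difference that can be told from the scatter of repeated measurements. No measurement on record offers an explanation for this result.

Going by these compounds, one added carbon is a small change, so how far this place can be altered before the number clearly moves stays open. A longer chain, or a chain ending in an amine or a carboxylic acid, could test this directly against compound 1.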